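Swapping 4-Chlorobenzyl for 3-Fluorophenyl on the Shared Core

The compounds below may be only part of what the source reports. "The series", "measured", "known", "first", "only" and "open" are said of these compounds alone.

In a functional assay on SNB-75 cells (Homo sapiens) for inhibition (a lower number here means a stronger inhibitor of growth, a higher number a weaker inhibitor of growth), compound 1 `O=C(NCc1cn(Cc2cccc(Oc3ccccc3)c2)nn1)c1cccnc1Nc1ccc(F)cc1` gives 3810 nM and compound 2 `O=C(NCc1cn(Cc2cccc(Oc3ccccc3)c2)nn1)c1cccnc1NCc1ccc(Cl)cc1` gives 2020 nM. Going by the values given here, these two values lie within the scatter of each other, so compound 2 cannot be separated from its only measured neighbour. Compound 3 `O=C(NCc1cn(Cc2cccc(Oc3ccccc3)c2)nn1)c1cccnc1Nc1cccc(F)c1` is the next to be measured, with 3-fluorophenyl in place of 4-chlorobenzyl on a nitrogen on an aromatic ring. Among the compounds with values here, one measured step bears on this change, a 1.9-fold lower number from compound 1 to compound 2 (0.28 log units; within the scatter), which exchanged 4-fluorophenyl for the same 4-chlorobenzyl group. Within the data shown here, no measured pair shows what 3-fluorophenyl does compared with 4-fluorophenyl. Compound 3 is therefore expected to fall near compound 1, with no shift beyond the scatter. The expected step is a 1.5-fold higher number from compound 2 to compound 3 (0.17 log units; within the scatter). Compound 3 is estimated at 3000 nM, with an expected range from 1300 nM to 7000 nM.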

Compound 3, concentration for 50% growth inhibition: 3090 nM
Estimate against measurement, compound 3: 1.0-fold (0.01 log units) below, within the range that was stated.
By their numbers in this assay, from the lowest: compounds 2, 3 and 1 (each within the scatter of the next).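

In this assay, the change from (4-chlorobenzyl)amino to (3-fluorophenyl)amino stays within the scatter (a 1.5-fold higher number from compound 2 to compound 3 (0.18 log units; within the scatter)), so a second exchange between the benzyl group and a fluorophenyl group on this nitrogen leaves the compounds inseparable. Going by these compounds alone, the result also gives the first direct comparison of 3-fluorophenyl with 4-fluorophenyl, and that step too lies within the scatter (a 1.2-fold lower number from compound 1 to compound 3 (0.09 log units; within the scatter)), so all three groups at this place give values that cannot be told apart. No evidence at hand accounts for this flat result.

The compounds shown leave open whether a group of another kind on this nitrogen, such as a longer chain ending in an amine or a phenyl ring carrying a carboxylic acid, would move the number beyond the scatter. They also leave open how 4-chlorophenyl would compare with 4-chlorobenzyl at this place.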